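The compounds below may be only part of what the source reports. "The series", "measured", "known", "first", "only" and "open" are said of these compounds alone.

Working notes on the series. In a functional assay on RS4-11 cells (Homo sapiens) for inhibition, read by CCK-8 assay, with a stated time of 48 h (on this read-out higher numbers stand for weaker inhibition and lower numbers for stronger inhibition), compound 1 `COc1ccc(Oc2ccccc2-c2ccsc2S(=O)(=O)N2CCN(C(=S)Nc3ccc([N+](=O)[O-])cc3)CC2)cc1OC` gives > 50000 nM as its result, which is a limit and not a number. Compound 2 `O=S(=O)(NCCNC(=S)Nc1cccc(Cl)c1)c1ccc(-c2ccccc2OCc2ccccc2)s1` gives > 50000 nM as its result, again a limit. Compound 3 `COc1cccc(NC(=O)NCCNS(=O)(=O)c2ccc(-c3ccccc3OCc3ccccc3)s2)c1` gives > 20000 nM as its result, also a limit. For the measured compounds named here, compound 1 therefore has no number to start from, and no compound measured so far has one either.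

Compound 4 `COc1ccc(Oc2ccc([N+](=O)[O-])cc2-c2ccsc2S(=O)(=O)N2CCN(C(=S)Nc3ccc([N+](=O)[O-])cc3)CC2)cc1OC` departs from compound 1 in one place: nitro in place of hydrogen on an aromatic carbon and, in words, nitro in place of hydrogen on an aromatic carbon, meta to a large group and para to a 3,4-dimethoxyphenoxy group.

Going by the values given here, the one measured step is a step that the two limits leave unreadable from compound 2 to compound 3 and it lies at a different place in a different pair, so it gives no size for this change. Among the compounds with values here, no measured step adds or removes a nitro group. In this assay no clear shift is therefore expected, though any readable number would lie on the side of stronger inhibition. The step expected is a number no higher from compound 1 to compound 4 (the limit leaves the size open) and it is an estimate only. Compound 4 is estimated at 50000 nM with an expected range from 10000 nM to 100000 nM on this read-out.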

Compound 4, half-maximal inhibitory concentration: > 50000 nM
Compound 4: no number, only a limit (the forecaster's own chance of this, stated with the estimate: 65%); the middle value lies on the limit itself.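

In this assay compound 4 gives > 50000 nM, which is a limit and not a number. Compound 1 also has only a limit, so no step can be read from compound 1 to compound 4. The compounds shown leave open whether nitro in place of hydrogen on an aromatic carbon shifts inhibition at all, and by how much.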